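The source may report more compounds than this note shows. Statements on the series, on what has been measured and on what is new or still open speak of the compounds shown alone.

Working notes on the series, values from a functional assay on the whole organism for antagonist activity, with Mus musculus as the target; a lower number here means that less compound is needed, a higher number that more compound is needed for the effect:

- compound 1 `Cn1c(-c2cccs2)nnc1S(C)(=O)=O`: > 200 mg/kg (a limit)
- compound 2 `CSc1nnc(-c2ccc(Cl)cc2)n1C`: > 200 mg/kg (a limit)
- compound 3 `Cn1nc(-c2ccccc2)nc1S(C)(=O)=O`: > 200 mg/kg (a limit)

In this assay, compound 3 has no numeric value, only > 200 mg/kg, which is a limit of the assay. It shares that position with the other two compounds, as the limit of > 200 mg/kg in this assay, at which 3 of the 3 values shown sit, shows. Among the measured compounds shown here, the series therefore holds no number and no measured step between compounds.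

The next compound is compound 4 `Cn1nc(-c2ccc(Cl)cc2)nc1S(C)(=O)=O`. It has chloro in place of hydrogen on an aromatic carbon of a six-membered aromatic ring of carbon only, para to a large group: chloro in place of hydrogen on an aromatic carbon.

For the measured compounds named here, with no measured step to scale from, the expectation is loose. A move towards less compound needed is expected, though a result at the same limit remains about as likely. The estimated change is an at least 1.6-fold lower number from compound 3 to compound 4 (0.22 log units; that floor lies within the scatter). If a number is reported, compound 4 is expected at 120 mg/kg, with an estimated range of 25 mg/kg to 400 mg/kg.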

Compound 4, dose for half-maximal effect: > 200 mg/kg
Compound 4 gave a limit, no number; the forecaster's own chance of this, stated with the estimate: 50%; middle value at least 1.6-fold (0.22 log units) away from the limit.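

In this assay compound 4 gives > 200 mg/kg, a limit of the assay. Compound 3 also stands at a limit, and the step between compound 3 and compound 4 cannot be read. The compounds shown leave open what dose any of them would need for the effect, with every value at one limit: the limit of > 200 mg/kg in this assay, at which 4 of the 4 values shown sit.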